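Amide nitrogen substituent and affinity in the adenosine carboxamide series

The source may report more compounds than this note shows. Statements on the series, on what has been measured and on what is new or still open speak of the compounds shown alone.

Measured compounds in an assay on cell membranes for binding affinity to 2-oxoglutarate receptor 1 (Rattus norvegicus), read by radioligand binding; a higher number here means a weaker inhibitor, a lower number a stronger inhibitor:
compound 1 `CCCCNC(=O)[C@H]1OC(n2cnc3c(N)ncnc32)[C@H](O)[C@@H]1O` gives 17 nM
compound 2 `CCCCCNC(=O)[C@H]1O[C@@H](n2cnc3c(N)ncnc32)[C@H](O)[C@@H]1O` gives 12 nM
compound 3 `CC(C)(C)NC(=O)[C@H]1O[C@@H](n2cnc3c(N)ncnc32)[C@H](O)[C@@H]1O` gives 6850 nM

Compound 1 stands second highest of the three numbers. Compound 2 lies a little lower, within the scatter, so the two cannot be ordered. For the measured compounds named here, compound 3 lies far above both; the single counted step, a 570-fold higher number from compound 2 to compound 3 (2.76 log units; beyond the scatter), shows that a change on the amide-type nitrogen can move this assay by a large amount.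

Compound 4 `Nc1ncnc2c1ncn2C1O[C@H](C(=O)NO)[C@@H](O)[C@H]1O` differs from compound 1 by hydroxy in place of butyl on an amide-type nitrogen; cut one bond further out, butylcarbamoyl becomes hydroxycarbamoyl. Going by the values given here, no measured step covers this exchange. Among the compounds with values here, the only step on the same nitrogen, from compound 2 to compound 3, went far beyond the scatter when the chain was replaced, and compounds 1 and 2, which carry unbranched chains, hold the lowest numbers. Within the data shown here, a step upward, beyond the scatter, is therefore expected, a 35-fold higher number from compound 1 to compound 4 (1.55 log units; beyond the scatter), though its size is uncertain since compound 3 is the only precedent.

Compound 4 is estimated at 600 nM, expected to fall between 60 nM and 6000 nM.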

Compound 4, inhibition constant: 41 nM
Compound 4: the middle estimate sits 15-fold (1.17 log units) above what was measured; measured number below the stated range.
By their numbers in this assay, from the lowest: compounds 2 and 1 (each within the scatter of the next); then compound 4; then compound 3.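

In this assay hydroxy in place of butyl on an amide-type nitrogen gives a 2.4-fold higher number from compound 1 to compound 4 (0.38 log units; beyond the scatter) and the step, though beyond the scatter, is modest. A low number at this position therefore does not depend on an alkyl chain: hydroxy, with 1 heavy atom against 4 for butyl and with a hydrogen-bond donor and acceptor that butyl lacks, stays in the same low range. The large step of a 570-fold higher number from compound 2 to compound 3 (2.76 log units; beyond the scatter) thus does not hold for every exchange on this nitrogen, and tert-butyl is the one group shown that goes against this.

On these data alone, whether methoxy, a plain amino group or a chain longer than pentyl would give a modest step or a large one remains open. Nothing at hand accounts for the difference in size between the hydroxy and tert-butyl steps.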